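The compounds below may be only part of what the source reports. "The series", "measured", "known", "first", "only" and "open" are said of these compounds alone.

Two measured analogues frame the question. Compound 1 `NS(=O)(=O)c1ccc(Nc2nc(N/N=C/c3ccc(C(F)(F)F)cc3)nc(Nc3ccccc3)n2)cc1` gives 35500 nM in a functional assay on RXF 393 cells (Homo sapiens) for inhibition, read by sulforhodamine B assay, with a stated time of 48 h (on this read-out lower numbers stand for higher toxicity in this test and higher numbers for lower toxicity in this test), whereas compound 2 `Cc1nn(-c2ccccc2)cc1/C=N/Nc1nc(Nc2ccccc2)nc(Nc2ccc(S(N)(=O)=O)cc2)n1` gives 6500 nM in this assay, the lowest of the two numbers. Compound 3 `NS(=O)(=O)c1ccc(Nc2nc(N/N=C/c3ccccn3)nc(Nc3ccccc3)n2)cc1` differs from compound 2 by pyridin-2-yl in place of 3-methyl-1-phenyl-1H-pyrazol-4-yl on a carbon with a double bond to nitrogen. Within the data shown here, the only measured step that bears on this change, on the same carbon with a double bond to nitrogen, is a 5.5-fold lower number from compound 1 to compound 2 (0.74 log units; beyond the scatter), a modest move. A modest step back toward higher numbers is therefore expected, estimated as a 2.3-fold higher number from compound 2 to compound 3 (0.36 log units; beyond the scatter). Compound 3 is expected to give 15000 nM, with a range from 5000 nM to 45000 nM.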

Compound 3, concentration lethal to 50% of the cells: 6510 nM
Compound 3: the middle estimate sits 2.3-fold (0.36 log units) above what was measured; measured number inside the range.
By their numbers in this assay, from the lowest: compounds 2 and 3 (each within the scatter of the next); then compound 1.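

Swapping 3-methyl-1-phenyl-1H-pyrazol-4-yl for pyridin-2-yl on the carbon with a double bond to nitrogen gives (a 1.0-fold higher number from compound 2 to compound 3 (0.00 log units; within the scatter)) in this assay, so the larger group is not needed to keep the number of compound 2. The step (a 5.5-fold lower number from compound 1 to compound 3 (0.74 log units; beyond the scatter)) shows that two different groups at this place both part from 4-(trifluoromethyl)phenyl. Nothing available explains this result. The compounds shown leave open whether a plain phenyl, a pyridin-4-yl or a pyridin-2-yl carrying an amine would stay with compound 2 and compound 3 or return toward compound 1.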